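This account rests on a few compounds, and the source may have more. Where it says the series, first, only, none or still open, it means among the compounds named here.

In a functional assay on Venous blood for antagonist activity at C-X-C chemokine receptor type 3 (Homo sapiens), read by flow cytometry, with a stated time of 30 min, in the presence of a further agent that is not named here (on this read-out higher numbers stand for weaker inhibition and lower numbers for stronger inhibition), three compounds have been measured so far. Compound 1 `C[C@@H]1CN(c2sc(C(F)(F)F)nc2-c2nc3ccccc3[nH]2)CCN1C(=O)Cn1ccc(C(=O)O)n1` gives 5570 nM, the highest number of the three. Compound 2 `Cc1nc(C)n(CC(=O)N2CCN(c3sc(C(F)(F)F)nc3-c3nc4c(F)cccc4[nH]3)C[C@H]2C)n1` gives 321 nM, and compound 3 `Cc1nc(C)n(CC(=O)N2CCN(c3sc(C(F)(F)F)nc3-c3nc4ccc(C(C)(C)O)c(F)c4[nH]3)C[C@H]2C)n1` gives 628 nM; both of these numbers lie beyond the usual scatter from that of compound 1, so both compounds inhibit more strongly than compound 1. Each of them, however, differs from compound 1 in more than one place, so no single structural step can be read from those pairs.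

Compound 4 `C[C@@H]1CN(c2sc(C(F)(F)F)nc2-c2nc3ccccc3[nH]2)CCN1C(=O)Cn1cnc2c1CCN(C)C2` has not yet been measured. It differs from compound 1 in one place only: a group of 10 heavy atoms (7 carbon, 3 nitrogen; one five-membered aromatic ring with 2 hetero atoms, one six-membered non-aromatic ring with 1 hetero atom) in place of a group of 8 heavy atoms (4 carbon, 2 nitrogen, 2 oxygen; one five-membered aromatic ring with 2 hetero atoms), on a saturated chain carbon bound to a carbonyl carbon. In other words, the 3-carboxy-1H-pyrazol-1-yl group leaves, and a group with one five-membered aromatic ring with 2 hetero atoms and one six-membered non-aromatic ring with 1 hetero atom enters, on a saturated chain carbon bound to a carbonyl carbon.

A step toward a lower number, that is stronger inhibition, is expected from compound 1 to compound 4, because compound 2 gives 321 nM and compound 3 gives 628 nM while neither carries the 3-carboxy-1H-pyrazol-1-yl group. The expected step is a 7.0-fold lower number from compound 1 to compound 4 (0.84 log units; beyond the scatter). Compound 4 is therefore estimated at 800 nM, within a range from 200 nM to 3500 nM.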

Compound 4, half-maximal inhibitory concentration: 135 nM
Beside the measured number, compound 4's estimate is 5.9-fold (0.77 log units) above it, outside the stated range (below it).
By their numbers in this assay, from the lowest: compound 4; then compounds 2 and 3 (each within the scatter of the next); then compound 1.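

Going by these compounds alone, this is the first direct reading of this position: with the core of compound 1 left unchanged, replacing the 3-carboxy-1H-pyrazol-1-yl group on the saturated chain carbon bound to a carbonyl carbon gives a 41-fold lower number from compound 1 to compound 4 (1.62 log units; beyond the scatter) in this assay, so the group at this one place can strongly shift the inhibition measured. The swap changes several things at once: the leaving group has 1 hydrogen-bond donor and the entering group has 0, both have 3 hydrogen-bond acceptors, and the entering group adds a six-membered non-aromatic ring with 1 hetero atom. Nothing available here explains why the step is so large.

The compounds shown cannot separate the loss of the carboxylic acid from the gain of the second ring, a question that a plain pyrazol-1-yl group or a pyrazol-1-yl group carrying an aminomethyl chain at the same place could help to answer. From the compounds shown here alone, it also remains open whether the entering group would have a similar effect on a core carrying the fluorine of compound 2, or whether a simple open-chain amine such as a dimethylamino group could take its place.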